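The source may report more compounds than this note shows. Statements on the series, on what has been measured and on what is new or still open speak of the compounds shown alone.

Compound 2 `O=c1[nH]c(=O)n([C@H]2C[C@H](O)[C@@H](COP(=O)(O)Oc3ccccc3)O2)cc1F` gives the higher of the two numbers recorded in an ADME assay on a cell-free system (serum, Homo sapiens) for metabolic stability, read by HPLC, tested at 2 mM; on this read-out higher numbers stand for a longer-lived compound and lower numbers for a shorter-lived compound: compound 2 reaches 52.3 h, while compound 1 `O=C(O[C@H]1C[C@H](n2cc(F)c(=O)[nH]c2=O)O[C@@H]1COP(=O)(O)Oc1cccnc1)c1ccccc1` reaches 17.8 h, a gap beyond the scatter. Compound 1 differs from compound 2 in two places, so no single change can be read from that pair. Compound 3 `O=c1[nH]c(=O)n([C@H]2C[C@H](O)[C@@H](COP(=O)(O)Oc3cccnc3)O2)cc1F` carries one change from compound 2, (pyridin-3-yl in place of phenyl on an oxygen). Among the compounds with values here, no measured pair isolates this change. Given that compound 1, which also bears pyridin-3-yl, sits at 17.8 h, a modest decrease is expected, with the step of a 1.7-fold lower number from compound 2 to compound 3 (0.24 log units; within the scatter) in this assay. Compound 3 is estimated at 30 h, within 12 h to 70 h.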

Compound 3, half-life in the Homo sapiens assay: 19.9 h
For compound 3 the middle estimate is 1.5-fold (0.18 log units) above the measured one; measured number inside the range.
By their numbers in the Homo sapiens assay, from the lowest: compounds 1 and 3 (each within the scatter of the next); then compound 2.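

In the Homo sapiens assay the change to pyridin-3-yl on the oxygen bound to phosphorus gives a 2.6-fold lower number from compound 2 to compound 3 (0.42 log units; beyond the scatter), a step beyond the scatter, whereas in a physicochemical assay for metabolic stability, read by HPLC, tested at 2 mM (a higher number here means that the compound lasts longer, a lower number that the compound disappears faster), compound 2 gives 28 h and compound 3 gives 16.7 h, so the same change gives a 1.7-fold lower number from compound 2 to compound 3 (0.22 log units; within the scatter), which stays within it. With pyridin-3-yl in place, hydrogen in place of benzoyl in the Homo sapiens assay gives a 1.1-fold higher number from compound 1 to compound 3 (0.05 log units; within the scatter), also within the scatter. So the phenyl compound stands apart in serum, while benzoyl shows no readable effect there.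

Nothing given here explains these numbers. Open questions are how pyridin-4-yl or 4-chlorophenyl would behave on that oxygen, and whether benzoyl would matter alongside phenyl.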